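Trading nitro for trifluoromethyl in compound 2

This account rests on a few compounds, and the source may have more. Where it says the series, first, only, none or still open, it means among the compounds named here.

In a functional assay on HepG2 cells (Homo sapiens) for cytotoxicity, read by MTT assay, with a stated time of 24 h (a lower number here means a stronger inhibitor, a higher number a weaker inhibitor), compound 1 `Cc1ccc(S(=O)(=O)N2C/C(=C\c3cccnc3)C(=O)/C(=C/c3ccccc3F)C2)cc1` gives 4200 nM and compound 2 `O=C1/C(=C/c2cccnc2)CN(S(=O)(=O)c2ccc([N+](=O)[O-])cc2)C/C1=C\c1ccccc1F` gives 12800 nM. Compound 2 therefore holds the higher of the two numbers, which makes it the weaker inhibitor of this pair. Compound 3 `O=C1/C(=C/c2cccnc2)CN(S(=O)(=O)c2ccc(C(F)(F)F)cc2)C/C1=C\c1ccccc1F` differs from it in one group: trifluoromethyl in place of nitro on an aromatic carbon. That is trifluoromethyl in place of nitro on an aromatic carbon, para to a large group. Among the measured compounds shown here, only one measured step bears on this change: a 3.0-fold higher number from compound 1 to compound 2 (0.48 log units; beyond the scatter), a modest step with nitro in place of methyl. For the measured compounds named here, compound 3 loses that nitro, but no measured compound here carries trifluoromethyl, so only part of that step is expected to return. The estimated step is a 1.7-fold lower number from compound 2 to compound 3 (0.23 log units; within the scatter). For compound 3 the expected value in this assay is 7500 nM, with an estimated range of 2800 nM to 20000 nM.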

Compound 3, half-maximal inhibitory concentration: 2400 nM
For compound 3 the middle estimate is 3.1-fold (0.49 log units) above the measured one; the measured number lies below the stated range.
By their numbers in this assay, from the lowest: compounds 3 and 1 (each within the scatter of the next); then compound 2.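

At this position, trifluoromethyl in place of nitro gives a 5.3-fold lower number from compound 2 to compound 3 (0.73 log units; beyond the scatter) in this assay, so the higher number seen with nitro does not carry over to this other replacement of methyl. Methyl and trifluoromethyl cannot be told apart here, since the change between them is a 1.8-fold lower number from compound 1 to compound 3 (0.24 log units; within the scatter) in the same test, and among these three groups only nitro stands apart, with its steps to both others beyond the scatter. Nothing measured here explains why nitro stands apart.

Going by these compounds, whether nitro is unusual or other groups at this position would also raise the number remains open, and an amine, a carboxylic acid or a chlorine atom there would help to settle this. On these data alone, it is also open whether the same order would hold with other groups elsewhere on the shared core.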